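This account rests on a few compounds, and the source may have more. Where it says the series, first, only, none or still open, it means among the compounds named here.

Series in a functional assay on HepG2 cells (Homo sapiens) for cytotoxicity, read by MTT assay; on this read-out higher numbers stand for weaker inhibition and lower numbers for stronger inhibition:
- Compound 1 `C=CCOc1cc(/C=C/C(=O)c2ccc(OC)c3c2OC(C)(C)C=C3)ccc1OC`: > 10000 nM (a limit)
- Compound 2 `COc1ccc(/C=C/C(=O)c2ccc(OC)c3c2OC(C)(C)C=C3)cc1OCCO`: > 10000 nM (a limit)
- Compound 3 `COc1ccc(/C=C/C(=O)c2ccc(OC)c3c2OC(C)(C)C=C3)cc1OCCCN(C)C`: not yet measured

Compound 2 has only a limit, > 10000 nM, and no number. Among the compounds with values here, the series so far stands at the limit of > 10000 nM in this assay, at which 2 of the 2 values shown sit. The change to compound 3 is (dimethylamino)methyl in place of hydroxy on a saturated chain carbon, two bonds along the chain from an oxygen on an aromatic ring. Within the data shown here, the one measured step, a step that the two limits leave unreadable from compound 1 to compound 2, offers no size to carry over. The expected step in this assay is an at least 1.1-fold lower number from compound 2 to compound 3 (0.04 log units; that floor lies within the scatter), a tentative expectation of stronger inhibition, with a reading at the limit again quite possible. For compound 3 the estimated value is 9000 nM, with an expected range of 3000 nM to 20000 nM.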

Compound 3, half-maximal inhibitory concentration: 5550 nM
Compound 3: middle estimate off by 1.6-fold (0.21 log units), on the high side; the measured number falls inside the stated range.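

Within the data shown here, replacing 2-hydroxyethoxy with 3-(dimethylamino)propoxy gives the first number in this assay, a step read as an at least 1.8-fold lower number from compound 2 to compound 3 (0.25 log units; that floor lies within the scatter). The second readable step is an at least 1.8-fold lower number from compound 1 to compound 3 (0.25 log units; that floor lies within the scatter); both are floors only, and the step between the two earlier compounds cannot be read. The true size of these steps stays unknown, and the series still sits largely at a limit: the limit of > 10000 nM in this assay, at which 2 of the 3 values shown sit.

The compounds shown do not separate the amine from the longer chain. A 3-hydroxypropoxy or 2-(dimethylamino)ethoxy group at this place would bear on that question.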